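A few compounds are considered here, and "the series" means these few. Any claim that something is new, unique, unknown or untested is made for them only; others in the source may bear on it.

Of the compounds shown here, three of one series have been tested in a functional assay on SW480 cells (Homo sapiens) for cytotoxicity, read by MTT assay, with a stated time of 4 days; on this read-out lower numbers stand for stronger inhibition and higher numbers for weaker inhibition. Compound 1 `C=C1C[C@]23C[C@@]1(O)CC[C@H]2c1ccc(O)c(C)c1[C@@H]3Cn1cc(-c2ccccn2)nn1` reaches only the limit of the assay, giving > 20000 nM. Compound 2 `C=C1C[C@]23C[C@@]1(O)CC[C@H]2c1ccc(OS(=O)(=O)c2ccc(C)cc2)c(C)c1[C@@H]3Cn1cc(-c2ccc(C)cc2)nn1` likewise shows only a limit, > 20000 nM. Compound 3 `C=C1C[C@]23C[C@@]1(O)CC[C@@H]2c1cccc(C)c1[C@@H]3Cn1cc(-c2ccc(Cl)cc2)nn1`, the starting point of the step followed here, also stops at the limit, with > 20000 nM. All three fall under one description: the limit of > 20000 nM in this assay, at which 3 of the 3 values shown sit. For the measured compounds named here, no measured step between them can be stated, and compound 3 stands with the others at that limit, separated from none of them by a number.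

Compound 4 `C=C1C[C@]23C[C@@]1(O)CC[C@@H]2c1cccc(C)c1[C@@H]3Cn1cc(-c2ccccc2)nn1` differs from compound 3 by hydrogen in place of chloro on an aromatic carbon. Going by the values given here, with every value shown resting at the limit, there is no measured step from which a direction could be read. The expected step is a step that the limit leaves unreadable from compound 3 to compound 4, that is none beyond the scatter. For compound 4 the estimate is 40000 nM, with a range from 10000 nM to 200000 nM, and most likely this assay again reports only a limit.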

Compound 4, half-maximal inhibitory concentration: > 20000 nM
Compound 4 gave a limit, no number; the forecaster's own chance of this, stated with the estimate: 85%; the middle value is on the limit's open side.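

In this assay no step can be read from compound 3 to compound 4, as both rest at the same limit: the limit of > 20000 nM in this assay, at which 4 of the 4 values shown sit. The compounds shown leave open how far each lies past that limit, and whether any change to the shared core would give a measurable value.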